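The source may report more compounds than this note shows. Statements on the series, on what has been measured and on what is new or still open speak of the compounds shown alone.

Of the compounds shown here, three built on one shared core have been measured in a physicochemical assay for solubility; a higher number here means a more soluble compound, a lower number a less soluble compound. Compound 1 `O=S(=O)(Nc1nccs1)c1ccc2c(c1)OCC[C@H]2c1ccc(C(F)(F)F)cc1-n1ccnn1` gives 154000 nM in this assay. Compound 2 `Cn1nccc1-c1cc(C(F)(F)F)ccc1[C@@H]1CCOc2cc(S(=O)(=O)Nc3nccs3)ccc21` gives 65000 nM, and the exchange of 1-methyl-1H-pyrazol-5-yl in place of 1H-1,2,3-triazol-1-yl on an aromatic carbon brought a 2.4-fold lower number from compound 1 to compound 2 (0.37 log units; beyond the scatter). Compound 3 `O=S(=O)(Nc1nccs1)c1ccc2c(c1)OCC[C@@H]2c1ccc(C(F)(F)F)cc1-c1nccs1` gives 15000 nM, the lowest of the three numbers; compound 2 stands nearest to it and compound 1 furthest, and both gaps lie beyond the scatter.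

Compound 4 `O=S(=O)(Nc1nccs1)c1ccc2c(c1)OCC[C@H]2c1ccc(C(F)(F)F)cc1-c1nccs1` is the next compound to be measured in this assay. Its difference from compound 3 is the two compounds have the same atoms and bonds and differ only in configuration as drawn: 1 of 1 stereo elements differ; a stereocentre at a saturated ring carbon is drawn R in compound 3 and S in compound 4. Nothing leaves and nothing enters; only the drawing at one saturated ring carbon changes, R in compound 3 and S in compound 4. For the measured compounds named here, none of the measured steps bears on such a change: the single step known, from compound 1 to compound 2, swaps one ring for another and so says nothing about configuration alone. Because compound 3 gives 15000 nM and compound 4 carries exactly its atoms and bonds, no step beyond the scatter is expected. The step expected from compound 3 to compound 4 is no change at the digits printed from compound 3 to compound 4 (within the scatter). Compound 4 is therefore estimated to give about 15000 nM, within a range from 7000 nM to 32000 nM.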

Compound 4, solubility: 7000 nM
Estimate against measurement, compound 4: 2.1-fold (0.33 log units) above; the range from low to high includes it.
By their numbers in this assay, from the lowest: compound 4; then compound 3; then compound 2; then compound 1.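

In this assay there is a 2.1-fold lower number from compound 3 to compound 4 (0.33 log units; beyond the scatter), and this step can be put down to the stereocentre at the saturated ring carbon alone, because nothing else separates the pair: the fact that compounds 3 and 4 differ only in the configuration as drawn. On the aromatic carbon, 1,3-thiazol-2-yl in place of 1-methyl-1H-pyrazol-5-yl gives a 9.3-fold lower number from compound 2 to compound 4 (0.97 log units; beyond the scatter), and 1,3-thiazol-2-yl in place of 1H-1,2,3-triazol-1-yl gives a 22-fold lower number from compound 1 to compound 4 (1.34 log units; beyond the scatter). Both of these ring exchanges are larger than the configuration step, so among these compounds the ring on that carbon moves the number more than the drawing at the stereocentre does, although the drawing still moves it beyond the scatter.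

From the compounds shown here alone, the 1H-1,2,3-triazol-1-yl and 1-methyl-1H-pyrazol-5-yl groups each appear here in a single configuration, so it remains open whether the same configuration step would appear with those rings. Also open, going by these compounds, is how this assay would read with an open-chain group such as an amine or a carboxylic acid on that aromatic carbon in place of a ring.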